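Azaindole for indole on the shared core, cytotoxicity

The source may hold more compounds than are shown below. What is called first, only, known or untested is meant among the compounds shown, and "the series" means these compounds.

Compound 2 `FC(F)(F)Oc1ccc(Nc2cc(-c3ccc4[nH]ccc4c3)ncn2)cc1` is the reference point. In an ADME assay on BaF3 cells (Mus musculus) for cytotoxicity (on this read-out higher numbers stand for an effect only at larger amounts of compound and lower numbers for an effect already at smaller amounts), compound 2 returns only the assay limit, > 10000 nM. Compound 1 `NC(=O)c1ccccc1-c1cc(Nc2ccc(OC(F)(F)F)cc2)ncn1` carries a 2-carbamoylphenyl group where compound 2 carries 1H-indol-5-yl. In this assay compound 1 likewise returns the assay limit, > 10000 nM. The step that the two limits leave unreadable from compound 1 to compound 2 is therefore unreadable because of the limit of > 10000 nM in this assay, at which 2 of the 2 values shown sit. Compound 3 `FC(F)(F)Oc1ccc(Nc2cc(-c3ccnc4[nH]ccc34)ncn2)cc1` differs from compound 2 in one place: a group of 9 heavy atoms (7 carbon, 2 nitrogen; one five-membered aromatic ring with 1 hetero atom, one six-membered aromatic ring with 1 hetero atom) in place of a group of 9 heavy atoms (8 carbon, 1 nitrogen; one five-membered aromatic ring with 1 hetero atom, one six-membered aromatic ring of carbon only), on an aromatic carbon. Going by the values given here, no measured step bears on this change; the only measured step in the set is the unreadable one just described. Both values shown sit at the limit, and compound 3 is expected to stay there too, with an expected step that the limit leaves unreadable from compound 2 to compound 3. The estimate for compound 3 in this assay is 15000 nM, within 5000 nM to 50000 nM, most likely again reported only as a limit.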

Compound 3, half-maximal effective concentration: 6850 nM
Beside the measured number, compound 3's estimate is 2.2-fold (0.34 log units) above it, within the range that was stated.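

Going by these compounds alone, compound 3 gives the only read number of the three in this assay, so this aromatic carbon can carry a group whose effect falls within the measurable range. The group entering in place of 1H-indol-5-yl carries 1 hydrogen-bond acceptor where the leaving group carries 0, and the change gives an at least 1.4-fold lower number from compound 2 to compound 3 (0.16 log units; that floor lies within the scatter). Against 2-carbamoylphenyl, the same group gives an at least 1.4-fold lower number from compound 1 to compound 3 (0.16 log units; that floor lies within the scatter); these are floors only, and the step between the two earlier compounds cannot be read, because the values at the limit set no size: the limit of > 10000 nM in this assay, at which 2 of the 3 values shown sit.

On these data alone, whether the true gap to compound 3 lies beyond the scatter remains open. Also open, as far as these compounds go, is how a pyridin-4-yl group or an aminophenyl group at this carbon would read in this assay.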